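The source may report more compounds than this note shows. Statements on the series, on what has been measured and on what is new or still open speak of the compounds shown alone.

Three compounds of a shared core, an aryl sulfone attached to a benzoxazole that carries a piperazine, have been measured in an assay on HeLa cells for displacement of a labelled ligand from 5-hydroxytryptamine receptor 6 (Homo sapiens); a lower number here means a stronger inhibitor, a higher number a weaker inhibitor. Compound 1 `O=S(=O)(c1cc(Cl)ccc1Cl)c1cccc2oc(N3CCNCC3)nc12` gives 13 nM in this assay. Compound 2 `O=S(=O)(c1ccc2nc(N3CCNCC3)oc2c1)c1cccc2ccccc12`, in which the sulfone sits at a different position of the core and bears a naphthyl group, gives 196 nM. With the naphthyl sulfone in the same position as in compound 1 and a methyl on the piperazine nitrogen, compound 3 `CN1CCN(c2nc3c(S(=O)(=O)c4cccc5ccccc45)cccc3o2)CC1` gives 9.7 nM. Compound 3 therefore holds the lowest number of the three; its separation from compound 1 lies within the usual scatter of this assay, so no order between those two can be claimed, while compound 2 stands far beyond the scatter above both.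

Compound 4 `O=S(=O)(c1cccc2ccccc12)c1cccc2oc(N3CCN(C4CCC4)CC3)nc12` has not yet been measured. It differs from compound 3 only in one place: cyclobutyl in place of methyl on an amine nitrogen in a ring. Within the data shown here, no measured pair isolates that change. Since compound 1, without any substituent on that nitrogen, and compound 3, with methyl, lie within the scatter of each other, the piperazine nitrogen appears tolerant of variation, and the step from compound 3 to compound 4 is expected to be small, perhaps a slight weakening, and likely to stay within the scatter: a 1.5-fold higher number from compound 3 to compound 4 (0.19 log units; within the scatter). Compound 4 is accordingly estimated to give 15 nM in this assay, with a range from 5 nM to 50 nM.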

Compound 4, inhibition constant: 72 nM
Estimate against measurement, compound 4: 4.8-fold (0.68 log units) below; measured number outside the range, above it.
By their numbers in this assay, from the lowest: compounds 3 and 1 (each within the scatter of the next); then compound 4; then compound 2.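

In this assay, putting cyclobutyl in place of methyl on the amine nitrogen of the piperazine ring gives a 7.4-fold higher number from compound 3 to compound 4 (0.87 log units; beyond the scatter). Among these compounds, this is the first pair that differs at this position alone, and it shows that the position does respond to what it carries: the earlier compounds offered no such pair, since compound 1 and compound 3 differ in more than one place, so their closeness could not settle the matter. Nothing shown offers an explanation for this step.

A single step cannot separate the added carbon count from the presence of the four-membered ring, so an open-chain group such as ethyl or isopropyl, or a smaller ring such as cyclopropyl, on the same nitrogen would be needed to tell whether the number rises gradually or only with a ring. Also open, from the compounds shown here alone, is how a chain ending in a hydroxyl group or an amine would behave at this nitrogen, and whether the same change would give a step of similar size with the 2,5-dichlorophenyl sulfone of compound 1.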